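A few compounds are considered here, and "the series" means these few. Any claim that something is new, unique, unknown or untested is made for them only; others in the source may bear on it.

Measured compounds:
compound 1 `CC1=C2CC(C)(C)/C=C/C/C(C)=C\C3=C[C@H](C)C[C@]3(O2)C1=O` — 26000 nM
compound 2 `CC1=C2CC(C)(C)[C@@H](C)CC(=O)/C(C)=C\C3=C[C@H](C)C[C@]3(O2)C1=O` — 26000 nM

In an ADME assay on BJ cells (Homo sapiens) for cytotoxicity, read by CellTiter-Glo, with a stated time of 72 h (a lower number here means that less compound is needed, a higher number that more compound is needed for the effect), compound 1 gives 26000 nM and compound 2 gives 26000 nM; the two values stand level within the scatter, so no ordering is drawn between them. Compound 3 `CC(=O)O[C@@H]1/C=C/C(C)(C)CC2=C(C)C(=O)[C@]3(C[C@@H](C)C=C3/C=C\1C)O2` is not yet measured in this assay. It differs from compound 1 by acetoxy in place of hydrogen on a saturated ring carbon. Going by the values given here, no step between measured compounds is known, so the size of the change in this assay is uncertain; none beyond the scatter is expected. The step is estimated at no change at the digits printed from compound 1 to compound 3 (within the scatter). Compound 3 is expected to give about 26000 nM, within 9000 nM to 70000 nM.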

Compound 3, half-maximal effective concentration: 26000 nM
Beside the measured number, compound 3's estimate shows no gap at the digits printed; measured number inside the range.
By their numbers in this assay, from the lowest: compounds 1, 2 and 3 (each within the scatter of the next).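

With acetoxy in place of hydrogen on a saturated ring carbon, next to the ring atom that bears a methyl group, this assay shows no change at the digits printed from compound 1 to compound 3 (within the scatter) and so gives the first step read at this position. The position therefore accepts acetoxy with no shift in the read-out, which compound 1 and compound 2 alone could not show. Nothing available explains this flat result. From the compounds shown here alone, whether an amine or a carboxylic acid on this carbon would also leave the value in place remains open. A single step gives no trend across substituents at this position.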